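A few compounds are considered here, and "the series" means these few. Any claim that something is new, unique, unknown or untested is made for them only; others in the source may bear on it.

Among the measured compounds shown here, in an in vitro ADME assay on microsomes (Mus musculus) for metabolic stability, read by LC-MS, with a stated time of 15 min (a higher number here means that the compound lasts longer, a lower number that the compound disappears faster), only two compounds have a result so far, and neither result is an exact number. Compound 1 `O=C(Nc1ccc(CO)cc1)Nc1ccc(-c2nc(N3C4CCC3COC4)nc(N3C4CCC3COC4)n2)cc1` gives > 0.5 h, which is a limit of the assay. Compound 2 `CCN1CCN(c2ccc(NC(=O)Nc3ccc(-c4nc(C5CCOCC5)nc(N5C6CCC5COC6)n4)cc3)cc2)CC1` gives > 0.5 h, which is also a limit. The position of compound 2 is therefore known only as the limit of > 0.5 h in this assay, at which 2 of the 2 values shown sit.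

Compound 3 `CN(C)C1CCN(C(=O)c2ccc(NC(=O)Nc3ccc(-c4nc(C5CCOCC5)nc(N5C6CCC5COC6)n4)cc3)cc2)CC1` differs from compound 2 in one place: it has (4-(dimethylamino)piperidin-1-yl)carbonyl in place of 4-ethylpiperazin-1-yl on an aromatic carbon, para to a large group ((4-(dimethylamino)piperidin-1-yl)carbonyl in place of 4-ethylpiperazin-1-yl on an aromatic carbon). For the measured compounds named here, no measured step shows what such a swap does, so no shift beyond the usual scatter is expected, in either direction. The estimated step is a step that the limit leaves unreadable from compound 2 to compound 3. The assay may well report only a limit again. For compound 3, the expected half-life is 0.6 h, with an estimated range of 0.25 h to 1.2 h.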

Compound 3, half-life: > 0.5 h
Compound 3 was reported as a limit; the forecaster's own chance of this, stated with the estimate: 65%; the middle value lies beyond the limit too.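

Among the compounds shown here, no step from compound 2 to compound 3 can be read, as each result is a limit of the assay and not an exact number: the limit of > 0.5 h in this assay, at which 3 of the 3 values shown sit. The compounds shown leave open how long each one actually lasts in this assay and whether (4-(dimethylamino)piperidin-1-yl)carbonyl in place of 4-ethylpiperazin-1-yl changes that at all.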